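Chloro in Place of Methyl: Expectation for Compound 3

The source may hold more compounds than are shown below. What is called first, only, known or untested is meant among the compounds shown, and "the series" means these compounds.

Measured so far:
Compound 1, `Cc1ccc(SCc2ccc(/C=C/C(=O)Nc3ccccc3N)cc2)cc1`: 6.23%
Compound 2, `Cc1ccc(SCc2ccc(C(=O)Nc3ccccc3N)cc2)cc1`: 74.8%

In a functional assay on HCT-116 cells (Homo sapiens) for inhibition, read by CCK-8 assay, with a stated time of 72 h, tested at 2 uM (a lower number here means less inhibition of growth, a higher number more inhibition of growth at the concentration tested), compound 2 gives 74.8%, the higher of the two numbers measured. Among the measured compounds shown here, the nearest value belongs to compound 1, which in this assay gives 6.23%; the gap between the two lies beyond the scatter of the measurement, and no step between them is worked out here, so only the two values speak for themselves.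

Compound 3, `Nc1ccccc1NC(=O)c1ccc(CSc2ccc(Cl)cc2)cc1`, has not yet been measured in this assay. It differs from compound 2 by chloro in place of methyl on an aromatic carbon. For the measured compounds named here, with no measured step of this kind to lean on, compound 3 is expected to stay near compound 2, and the step of a number 4.8 percentage points lower from compound 2 to compound 3 (within the scatter) is estimated to lie within the scatter, with no clear direction. Compound 3 is therefore expected to give 70% in this assay, within a range of 50% to 88%.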

Compound 3, percent growth inhibition at one concentration: 17.5%
Beside the measured number, compound 3's estimate is 52.5 percentage points above it, and the stated range ends above it.
By their numbers in this assay, from the lowest: compound 1; then compound 3; then compound 2.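

In this assay the exchange of 4-methylphenyl for 4-chlorophenyl comes out as a number 57.3 percentage points lower from compound 2 to compound 3 (beyond the scatter) and shows that this place, on an aromatic carbon para to a large group, is far from indifferent to what it carries. The earlier compounds shown here offered no step at this place, and here a swap of one heavy atom for another, with no change in ring, hydrogen-bond donors, acceptors or net charge, is enough for a large drop. Nothing available explains this drop.

From the compounds shown here alone, it remains open how other groups would read at this place, whether a fluoro, a methoxy, an amine or a carboxylic acid would stand nearer to compound 2 or to compound 3. Going by these compounds, it is equally open whether the same exchange would carry over to the core of compound 1.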